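Hydroxamic acid chain length on two cores, cell growth inhibition

A few compounds are considered here, and "the series" means these few. Any claim that something is new, unique, unknown or untested is made for them only; others in the source may bear on it.

Measured so far:
compound 1 `Nc1nc2cc(-c3nn(CCCCCCCCCC(=O)NO)c4ncnc(N)c34)ccc2o1`, 36800 nM
compound 2 `Nc1ncnc2c1c(-c1cnc3[nH]ccc3c1)nn2CCC(=O)NO`, > 150000 nM
compound 3 `Nc1nc2cc(-c3nn(CCCCCCCCC(=O)NO)c4ncnc(N)c34)ccc2o1`, 3240 nM

In a functional assay on CNE-2 cells (Homo sapiens) for inhibition, read by MTT assay, with a stated time of 72 h (a lower number here means a stronger inhibitor, a higher number a weaker inhibitor), compound 3 gives 3240 nM, and compound 1 gives 36800 nM. The value of compound 2 in this assay is a limit of the assay, not a number; it sits at the limit of > 150000 nM in this assay, at which 1 of the 3 values shown sits.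

Between compound 3 and compound 1 the change is (hydroxycarbamoyl)methyl in place of hydroxycarbamoyl on a saturated chain carbon, eight bonds along the chain from an aromatic nitrogen, and it made the step of an 11-fold higher number from compound 3 to compound 1 (1.06 log units; beyond the scatter).

Compound 4 `Nc1ncnc2c1c(-c1cnc3[nH]ccc3c1)nn2CCCC(=O)NO` is not yet measured. It stands to compound 2 as (hydroxycarbamoyl)methyl in place of hydroxycarbamoyl on a saturated chain carbon, two bonds along the chain from an aromatic nitrogen. The difference between the core of compound 2 and the core of compound 3 is not broken down here. For the measured compounds named here, the change is of the same kind as the one from compound 3 to compound 1, not the same: around the place it differs, two bonds along the chain from an aromatic nitrogen against eight bonds along the chain from an aromatic nitrogen, on a different core.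

Going by the values given here, the only measured step of this kind weakened inhibition, and compound 2 already sits at a limit, so compound 4 is expected to remain weak in this assay. That expectation rests on compound 2, whose value > 150000 nM is a limit of the assay. It rests also on the measured step of an 11-fold higher number from compound 3 to compound 1 (1.06 log units; beyond the scatter). For compound 4 the step of a number no higher from compound 2 to compound 4 (the limit leaves the size open) is the expected change. Compound 4 is expected near 150000 nM, between 30000 nM and 400000 nM.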

Compound 4, half-maximal inhibitory concentration: > 150000 nM
Compound 4: only a limit was reported; the forecaster's own chance of this, stated with the estimate: 60%; the middle value sits exactly at the limit.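

In this assay, compound 2 and compound 4 each give a limit of the assay rather than a number, so no step can be read between them: the limit of > 150000 nM in this assay, at which 2 of the 4 values shown sit.

The compounds shown leave open whether any hydroxamic acid chain on the core of compound 2 would give a readable value.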